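This account rests on a few compounds, and the source may have more. Where it says the series, first, only, none or still open, it means among the compounds named here.

Going by the values given here, in an assay for inhibition of beta-N-acetyl-D-hexosaminidase-A/B (Homo sapiens) (on this read-out higher numbers stand for weaker inhibition and lower numbers for stronger inhibition), compound 1 `CCc1nc(N)nc(N)c1-c1cccc(C)c1` gives 34000 nM, the only number among the three values at hand. Compound 2 `CCc1nc(N)ncc1-c1ccc(Cl)cc1` gives only a limit of the assay, > 400000 nM. Compound 3 `CC(C)c1nc(N)nc(N)c1-c1ccc(Cl)cc1` likewise gives only a limit, > 410000 nM. Among the compounds with values here, compound 1 is thus the one compound of the three placed by a number rather than a limit. Compound 4 `CCc1nc(N)nc(N)c1-c1cc(C)cc(C)c1` has not yet been measured in this assay; it differs from compound 1 by methyl in place of hydrogen on an aromatic carbon. Within the data shown here, no step between measured compounds is available, so the size of this change cannot be read from anything measured here. A step of a 1.4-fold lower number from compound 1 to compound 4 (0.13 log units; within the scatter) is expected, not beyond the scatter. Compound 4 is estimated at 25000 nM, with a range from 8000 nM to 90000 nM.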

Compound 4, half-maximal inhibitory concentration: 47000 nM
Beside the measured number, compound 4's estimate is 1.9-fold (0.27 log units) below it; measured number inside the range.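

Going by these compounds alone, the first step that can be read here is a 1.4-fold higher number from compound 1 to compound 4 (0.14 log units; within the scatter), so in this assay compound 4 cannot be told apart from its parent when a second methyl group is added, meta to a large group and meta to a methyl group. Compound 4 also joins compound 1 as a second compound placed by a number rather than a limit. Nothing measured here bears on this result.

From the compounds shown here alone, whether an amine, a carboxylic acid or a longer chain at this place would behave the same remains open. The steps involving compound 2 and compound 3 cannot be read, since both are limits of the assay.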